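A few compounds are considered here, and "the series" means these few. Any claim that something is new, unique, unknown or untested is made for them only; others in the source may bear on it.

Measured so far:
compound 1, `COc1cc(-c2cc(/C=C/C(=O)c3ccc(N)cc3)[nH]n2)cc(OC)c1OC`, 90%
compound 2, `COc1ccc(C(=O)/C=C/c2cc(-c3cc(OC)c(OC)c(OC)c3)n[nH]2)cc1`, 93%

In a functional assay on SK-MEL-5 cells (Homo sapiens) for cytotoxicity, read by sulforhodamine B assay, with a stated time of 48 h, tested at 1 uM (a higher number here means a weaker effect of the compound at the concentration tested, a lower number a stronger effect), compound 2 gives 93%, numerically the top of the two values, but the gap to compound 1 at 90% is within the scatter, and the step of a number 3 percentage points higher from compound 1 to compound 2 (within the scatter) does not separate the two. Compound 3, `COc1cc(-c2cc(/C=C/C(=O)c3ccc(F)c(F)c3)[nH]n2)cc(OC)c1OC`, has not been measured in this assay. It differs from compound 2 by 3,4-difluorophenyl in place of 4-methoxyphenyl on a carbonyl carbon. For the measured compounds named here, the only measured step, a number 3 percentage points higher from compound 1 to compound 2 (within the scatter), concerns a change on the group attached to the carbonyl carbon and stayed within the scatter; it gives no indication of how the pair of fluorines will read. Nothing in the two measured compounds points to a step beyond the scatter, so compound 3 is expected to give 90% (range 72% to 102%), an expected step of a number 3 percentage points lower from compound 2 to compound 3 (within the scatter). Going by the values given here, the range is kept wide because only the step of a number 3 percentage points higher from compound 1 to compound 2 (within the scatter) is available to anchor it.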

Compound 3, a percentage reported as activity, at one concentration (the size of the read-out at that concentration, not a potency): 90%
For compound 3 middle estimate and measured number coincide at the digits printed; measured number inside the range.
By their numbers in this assay, from the lowest: compounds 1, 3 and 2 (each within the scatter of the next).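

On the carbonyl carbon whose other neighbour is the double-bonded chain carbon, 3,4-difluorophenyl in place of 4-methoxyphenyl reads in this assay as a number 3 percentage points lower from compound 2 to compound 3 (within the scatter) and 3,4-difluorophenyl in place of 4-aminophenyl reads as no change at the digits printed from compound 1 to compound 3 (within the scatter) in the same assay. The earlier step exchanged only amino for methoxy on an aromatic carbon, whereas this one brings in two fluorines and removes the hydrogen-bond acceptor counted for 4-methoxyphenyl, yet the three compounds remain unseparated. No accompanying measurement bears on this reading.

On these data alone, whether any group at this carbonyl carbon gives a step beyond the scatter remains open, for example a carboxylic acid on the phenyl ring or a longer chain in place of it. As far as these compounds go, the contribution of the rest of the shared core also remains open.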